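The source may report more compounds than this note shows. Statements on the series, on what has been measured and on what is new or still open speak of the compounds shown alone.

Measured so far:
compound 1, `Cc1cccc(-c2ccc(CCC(=O)N3CCCC3)cc2)c1`: 16500 nM
compound 2, `O=C(CCc1ccc(-c2ccccc2Cl)cc1)N1CCCC1`: > 100000 nM

In an assay on HEK293 cells for inhibition of N-acylethanolamine-hydrolyzing acid amidase (Rattus norvegicus), read by LC-MS, with a stated time of 30 min (on this read-out higher numbers stand for weaker inhibition and lower numbers for stronger inhibition), compound 1 gives 16500 nM. For compound 2 this assay reports only a limit, > 100000 nM, so compound 2 sits at the limit of > 100000 nM in this assay, at which 1 of the 2 values shown sits. Among the measured compounds shown here, the sole measured step touching this ring, an at least 6.0-fold higher number from compound 1 to compound 2 (0.78 log units; beyond the scatter), was a weakening. Compound 3, `O=C(CCc1ccc(-c2cccc(Cl)c2)cc1)N1CCCC1`, differs from compound 2 by 3-chlorophenyl in place of 2-chlorophenyl on an aromatic carbon, which places the substituent as in compound 1, with its value of 16500 nM. A number below the limit is therefore expected for compound 3. Compound 3 is estimated at 25000 nM (range 6000 nM to 100000 nM). This expected step is an at least 4.0-fold lower number from compound 2 to compound 3 (0.60 log units; beyond the scatter).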

Compound 3, half-maximal inhibitory concentration: 25400 nM
Beside the measured number, compound 3's estimate is 1.0-fold (0.01 log units) below it; the measured number falls inside the stated range.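

The step of an at least 3.9-fold lower number from compound 2 to compound 3 (0.59 log units; beyond the scatter) shows that with chlorine on both compounds, the place of the substituent alone separates 2-chlorophenyl from 3-chlorophenyl, which the earlier step could not show because it changed both group and place. Chloro in place of methyl, with 3-methylphenyl and 3-chlorophenyl compared, gives a 1.5-fold higher number from compound 1 to compound 3 (0.19 log units; within the scatter), so these two are not separated. The value of compound 2 remains a limit: the limit of > 100000 nM in this assay, at which 1 of the 3 values shown sits.

Open, from the compounds shown here alone, is what an amine or a carboxylic acid in place of the chlorine would give. Also open, going by these compounds, is whether the effect of place holds for groups other than chloro.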